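The source may report more compounds than this note shows. Statements on the series, on what has been measured and on what is new or still open speak of the compounds shown alone.

Measured compounds:
compound 1 `CS(=O)(=O)Nc1ccc2c(c1)S(=O)(=O)N=C(C1=C(O)[C@H]3CCC[C@H]3N(Cc3ccc(F)c(F)c3)C1=O)N2` gives 1.2 mL/min/kg in an in vivo ADME assay on the whole organism for pharmacokinetics, with Cynomolgus monkey (Macaca fascicularis) as the target, at a dose of 1 mg/kg by the intravenous route; a lower number here means slower removal, a higher number faster removal of the compound
compound 2 `CS(=O)(=O)Nc1ccc2c(c1)S(=O)(=O)N=C(C1=C(O)[C@H]3CCCC[C@H]3N(Cc3ccc(F)cc3)C1=O)N2` gives 0.7 mL/min/kg in this assay

In this assay compound 2 gives 0.7 mL/min/kg, and compound 1 gives 1.2 mL/min/kg; the gap between them lies within the usual scatter, so neither can be called the slower or faster cleared of the two. Compound 3 `CS(=O)(=O)Nc1ccc2c(c1)S(=O)(=O)N=C(C1=C(O)[C@@H]3CCCC[C@@H]3N(Cc3ccc(F)cc3)C1=O)N2` is the next compound. It differs from compound 2 in one way: the two compounds have the same atoms and bonds and differ only in configuration as drawn: 2 of 2 stereo elements differ (all stereocentres are inverted: mirror images); a stereocentre at a saturated ring carbon is drawn S in compound 2 and R in compound 3; a stereocentre at a saturated ring carbon is drawn R in compound 2 and S in compound 3. Among the measured compounds shown here, no step between two measured compounds of this kind is known here, so there is nothing to show how a mirror image changes the number in this assay. Both measured compounds sit at low clearance, and compound 3 keeps every atom and bond of compound 2. The expected step of a 1.3-fold higher number from compound 2 to compound 3 (0.11 log units; within the scatter) is therefore none beyond the scatter, in either direction. Compound 3 is expected to give 0.9 mL/min/kg in this assay, with a range from 0.3 mL/min/kg to 3 mL/min/kg.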

Compound 3, clearance: 1.7 mL/min/kg
Beside the measured number, compound 3's estimate is 1.9-fold (0.28 log units) below it, within the range that was stated.
By their numbers in this assay, from the lowest: compounds 2, 1 and 3 (each within the scatter of the next, the first and the last beyond it).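

Among the compounds shown here, the mirror-image pair gives the first reading of how handedness acts at these two saturated ring carbons, which neither compound 1 nor compound 2 could give alone: a 2.4-fold higher number from compound 2 to compound 3 (0.39 log units; beyond the scatter). The step is modest, but it lies beyond the scatter, so in this assay the drawn configuration at these carbons counts for something even with every atom and bond kept. The step can be laid to the inversion alone, because one fact excludes any other change: the fact that compounds 2 and 3 differ only in the configuration as drawn

Both stereocentres flip together here, so the compounds shown leave open whether one centre carries the step or both share it, which a compound with only one centre inverted would address. Also open, from the compounds shown here alone, is whether the same inversion would give a similar step in a compound carrying another group, such as a carboxylic acid or an amine, on the shared core.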